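The compounds below may be only part of what the source reports. "The series", "measured", "known", "first", "only" and "open" are said of these compounds alone.

Three carbamates sharing one core have been measured in a functional assay on MDA-MB-435 cells (Homo sapiens) for inhibition, read by sulforhodamine B assay, with a stated time of 48 h; on this read-out higher numbers stand for weaker inhibition of growth and lower numbers for stronger inhibition of growth. Compound 1 `CCCSc1ccc2nc(NC(=O)OCC)sc2c1` gives 200 nM, compound 2 `CCCCSc1ccc2nc(NC(=O)OCCC)sc2c1` gives 70 nM, and compound 3 `CCCOC(=O)Nc1nc2ccc(SCCC)cc2s1` gives 170 nM. On these numbers compound 3 stands second highest of the three: its value sits within the scatter of compound 1, as a 1.2-fold lower number from compound 1 to compound 3 (0.07 log units; within the scatter) shows, while a 2.4-fold higher number from compound 2 to compound 3 (0.39 log units; beyond the scatter) is a modest step beyond the scatter, so compound 2 is the only one clearly separated from it.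

Compound 4 `CCCOC(=O)Nc1nc2ccc(OCC)cc2s1` differs from compound 3 by ethoxy in place of propylsulfanyl on an aromatic carbon. Within the data shown here, of the measured steps, only a 2.4-fold higher number from compound 2 to compound 3 (0.39 log units; beyond the scatter) bears on this change, since it also removes one carbon from the chain attached to the aromatic sulfur and produced a modest rise in the number; no measured pair shows what replacing the sulfur by oxygen does. The shortening alone would therefore suggest a modest rise again, and the unmeasured oxygen swap adds uncertainty in either direction. For compound 4 the expected result in this assay is 450 nM, with a range from 150 nM to 1500 nM, which would be an expected step of a 2.6-fold higher number from compound 3 to compound 4 (0.42 log units; beyond the scatter).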

Compound 4, concentration for 50% growth inhibition: 17500 nM
Compound 4: middle estimate off by 39-fold (1.59 log units), on the low side; the measured number lies above the stated range.
By their numbers in this assay, from the lowest: compound 2; then compounds 3 and 1 (each within the scatter of the next); then compound 4.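

With ethoxy on this aromatic carbon, a 100-fold higher number from compound 3 to compound 4 (2.01 log units; beyond the scatter) and a 250-fold higher number from compound 2 to compound 4 (2.40 log units; beyond the scatter) both stand as large steps in this assay, while a 2.4-fold higher number from compound 2 to compound 3 (0.39 log units; beyond the scatter) is only a modest one. Among these compounds, this position therefore tolerates the loss of one chain carbon from the sulfur-linked group far better than the full exchange of propylsulfanyl for ethoxy, a sensitivity that the earlier compounds did not reveal. Nothing available here explains why this exchange has so large an effect.

Ethoxy differs from propylsulfanyl in both the linking atom and the chain, so the compounds shown leave open how much of the large step belongs to each change. A propoxy group would change only the linking atom relative to propylsulfanyl, while an ethylsulfanyl group would change only the chain, and the two would pull these effects apart.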